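Methoxy Addition on Two Related Cores

The source may hold more compounds than are shown below. What is called first, only, known or untested is meant among the compounds shown, and "the series" means these compounds.

Compound 1, `COc1cc(/C=C/C2CC=CC(=O)O2)cc(OC)c1`: in a functional assay on 786-0 cells (Homo sapiens) for inhibition, read by sulforhodamine B assay, with a stated time of 48 h (on this read-out lower numbers stand for stronger inhibition of growth and higher numbers for weaker inhibition of growth), compound 1 gives 10.6 uM.
Compound 2, `COc1cc(/C=C/C2CC=CC(=O)O2)cc(OC)c1OC`: compound 2 gives 18.5 uM.
Compound 3, `COc1cc(/C=C/C2CC=CC(=O)N2)cc(OC)c1`: compound 3 gives 173 uM.

The change from compound 1 to compound 2 is methoxy in place of hydrogen on an aromatic carbon, and it brought a 1.7-fold higher number from compound 1 to compound 2 (0.24 log units; within the scatter). The difference between the core of compound 1 and the core of compound 3 is not broken down here; compound 3 stands at the highest number of the three, beyond the scatter from both others. Compound 4, `COc1cc(/C=C/C2CC=CC(=O)N2)cc(OC)c1OC`, carries the same change on the core of compound 3, (methoxy in place of hydrogen on an aromatic carbon), at the same place as before. Because that change earlier gave a 1.7-fold higher number from compound 1 to compound 2 (0.24 log units; within the scatter), the expected step in this assay is a 1.4-fold higher number from compound 3 to compound 4 (0.16 log units; within the scatter), a small one. Compound 4 is therefore estimated at 250 uM, expected between 100 uM and 600 uM.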

Compound 4, concentration for growth inhibition (reported as GI): > 864 uM
Compound 4: only a limit was reported; the forecaster's own chance of this, stated with the estimate: 15%; middle value at least 3.4-fold (0.53 log units) from the limit.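

In this assay compound 4 gives > 864 uM, which is a limit of the assay and not a number. Methoxy in place of hydrogen on an aromatic carbon brought an at least 4.9-fold higher number from compound 3 to compound 4 (0.69 log units; beyond the scatter), and the change of core with that group present brought an at least 46-fold higher number from compound 2 to compound 4 (1.66 log units; beyond the scatter), so the addition did not carry over at the same size from one core to the other: the same change on two cores in this assay, a 1.7-fold higher number (0.24 log units; within the scatter) from compound 1 to compound 2 and an at least 4.9-fold higher number (0.69 log units; beyond the scatter) from compound 3 to compound 4, at least 2.8-fold (0.45 log units) apart, beyond the scatter of two such steps The full size of the step on the core of compound 3 stays unknown, and two cores give neither a reason for the gap nor a rule for the series: the limit of > 864 uM in this assay, at which 1 of the 4 values shown sits.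

The compounds shown leave open whether a different group at the same place, such as a hydroxyl or an ethoxy, would behave alike on both cores. They also leave open whether an amine there would do so.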